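The compounds below may be only part of what the source reports. "The series", "measured", "known", "first", "only" and "open" are said of these compounds alone.

In a functional assay on KB cells (Homo sapiens) for inhibition, read by MTT assay, with a stated time of 24 h, tested at 100 ug/mL (on this read-out higher numbers stand for more inhibition of growth at the one concentration tested and lower numbers for less inhibition of growth), three compounds sharing one core have been measured. Compound 1 `O=C(CCCCC(S)CCS)Nc1ccc(Cl)cc1` gives 44.1%, and compound 2 `O=C(CCCCC(S)CCS)Nc1ccc(OC(F)(F)F)cc1` gives 73.3%. Compound 3 `O=C(CCCCC(S)CCS)Nc1ccc([N+](=O)[O-])c(C(F)(F)F)c1` gives 95.5%, the highest of the three and beyond the scatter of both others. The next compound, compound 4 `O=C(CCCCC(S)CCS)Nc1ccc([N+](=O)[O-])cc1`, has hydrogen in place of trifluoromethyl on an aromatic carbon. Going by the values given here, only one measured step offers any guide, and only indirectly: a number 29.2 percentage points higher from compound 1 to compound 2 (beyond the scatter), a modest step beyond the scatter, with trifluoromethoxy in place of chloro on an aromatic carbon. Among the compounds with values here, no measured step removes a trifluoromethyl group, so the data do not fix the size of this change. Within the data shown here, with compound 3 already at 95.5%, there is little room for a rise, and a fall somewhat smaller than the one measured step is expected, though still beyond the scatter. The estimated step is a number 23.5 percentage points lower from compound 3 to compound 4 (beyond the scatter). The expected value for compound 4 is 72%, with an estimated range from 48% to 95%.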

Compound 4, percent growth inhibition at one concentration: 41.1%
Compound 4: middle estimate off by 30.9 percentage points, on the high side; the measured number lies below the stated range.
By their numbers in this assay, from the lowest: compounds 4 and 1 (each within the scatter of the next); then compound 2; then compound 3.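

In this assay, going by these compounds alone, the position ortho to a nitro group proves highly sensitive to substitution, as hydrogen in place of trifluoromethyl gives a number 54.4 percentage points lower from compound 3 to compound 4 (beyond the scatter), the first measured change at this position. With hydrogen there, the nitro compound no longer stands apart from the chloro compound, as nitro in place of chloro gives a number 3 percentage points lower from compound 1 to compound 4 (within the scatter), whereas nitro in place of trifluoromethoxy gives a number 32.2 percentage points lower from compound 2 to compound 4 (beyond the scatter). Nothing available explains the size of the trifluoromethyl step.

As far as these compounds go, what a methyl group, a chlorine atom or a nitrile would give in place of trifluoromethyl, ortho to a nitro group, remains open. From the compounds shown here alone, it also remains open whether trifluoromethyl would give a comparable step with a hydrogen atom or an amine in place of the nitro group.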